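This account rests on a few compounds, and the source may have more. Where it says the series, first, only, none or still open, it means among the compounds named here.

Compound 1, `Nc1cc(N)c2nc(-c3ccccc3)c(Oc3ccc(Cl)c(Cl)c3)nc2c1`: < 100000 nM in this assay, a limit rather than a number.
Compound 2, `COc1ccc(CNc2nc3cc(N)cc(N)c3nc2-c2ccccc2)cc1OC`: < 100000 nM, again a limit.
Compound 3, `COc1cc(CNc2nc3cc(N)cc(N)c3nc2-c2ccccc2)cc(OC)c1OC`: < 50200 nM, also a limit.

In a functional assay on RXF 393 cells (Homo sapiens) for inhibition, read by sulforhodamine B assay, with a stated time of 48 h (on this read-out lower numbers stand for higher toxicity in this test and higher numbers for lower toxicity in this test), compound 1 gives < 100000 nM, which is a limit of the assay. Compound 2 gives < 100000 nM, likewise a limit. Compound 3 gives < 50200 nM, also a limit. Compound 2 therefore stands only at a limit, with the limit of < 100000 nM in this assay, at which 2 of the 3 values shown sit, and the limit of < 50200 nM in this assay, at which 1 of the 3 values shown sits, the whole of the evidence. Going by the values given here, the one measured step, a step that the two limits leave unreadable from compound 2 to compound 3, gives no readable size. Compound 4, `COc1ccc(CNc2nc3cc(N)cc(N)c3nc2-c2ccccc2)cc1`, differs from compound 2 by hydrogen in place of methoxy on an aromatic carbon. No readable step bears on this change, so no shift beyond the scatter in this assay is expected in either direction. Compound 4 is expected near 30000 nM, between 5000 nM and 100000 nM. The estimated step is a step that the limit leaves unreadable from compound 2 to compound 4.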

Compound 4, concentration lethal to 50% of the cells: 44700 nM
The estimate for compound 4 lay 1.5-fold (0.17 log units) below the measured number, within the range that was stated.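

No step can be read from compound 2 to compound 4, because compound 2 stands only at a limit of the assay: the limit of < 100000 nM in this assay, at which 2 of the 4 values shown sit.

The compounds shown leave open whether 4-methoxyphenyl in place of 3,4-dimethoxyphenyl shifts the value in this assay at all, and by how much.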